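Stilbene-type analogues with an amine swap in the cell assay

The source may hold more compounds than are shown below. What is called first, only, known or untested is meant among the compounds shown, and "the series" means these compounds.

Two compounds from this series have been examined in a functional assay on L02 cells (Homo sapiens) for inhibition, read by Griess assay, with stated times of 1 h and 24 h; a higher number here means a weaker inhibitor, a lower number a stronger inhibitor. Compound 1, `COc1cc(/C=C/c2nc(Cl)cc(NC(C)C)n2)cc(OC)c1OC`, carries a chlorine and an isopropylamino group on its core; in this assay compound 1 returns only a limit, < 40000 nM, as the line the limit of < 40000 nM in this assay, at which 1 of the 2 values shown sits, records. Compound 2, `COc1cc(/C=C/c2nc(NC3CC3)c3sccc3n2)cc(OC)c1OC`, has a different fused core with a cyclopropylamino group; in this assay compound 2 likewise gives only a limit, > 1000000 nM, as the line the limit of > 1000000 nM in this assay, at which 1 of the 2 values shown sits, records, so compound 2 stands at the weak end of what has been seen. Compound 3, `COc1cc(/C=C/c2nc(N(C)c3ccccc3)c3sccc3n2)cc(OC)c1OC`, differs from compound 2 in one place: methyl(phenyl)amino in place of cyclopropylamino on an aromatic carbon. For the measured compounds named here, no step between measured compounds is available to calibrate this change, so the expectation rests on compound 2 alone. The author expects a step from compound 2 to compound 3 of an at least 1.6-fold lower number from compound 2 to compound 3 (0.22 log units; that floor lies within the scatter), within the usual scatter. For compound 3 the estimate in this assay is 600000 nM, ranging from 100000 nM to 3000000 nM, with a strong chance that only a limit is again reported.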

Compound 3, half-maximal inhibitory concentration: 767000 nM
Compound 3: middle estimate off by 1.3-fold (0.11 log units), on the low side; low and high end bracket the measured number.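

For the compounds shown here, compound 3 gives the first exact number on the core it shares with compound 2 in this assay, so a group at this position, next to the ring nitrogen, can now be tied to a real reading. The swap from cyclopropylamino, with its hydrogen-bond donor, to methyl(phenyl)amino, with none, gives an at least 1.3-fold lower number from compound 2 to compound 3 (0.11 log units; that floor lies within the scatter), which is only a floor and shows no real difference on its own. The other end of this step is not a number, as compound 2 stands only at a limit: the limit of > 1000000 nM in this assay, at which 1 of the 3 values shown sits.

As far as these compounds go, the true distance between the two compounds stays open, and the loss of the donor cannot be told apart from the arrival of the six-membered aromatic ring. Phenylamino, which would keep the donor alongside the aromatic ring, or morpholine would help separate the two.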